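From 2-isopropylphenyl to 3-methoxyphenyl on a shared core

A few compounds are considered here, and "the series" means these few. Any claim that something is new, unique, unknown or untested is made for them only; others in the source may bear on it.

Going by the values given here, in a functional assay on Jurkat cells (Homo sapiens) for inhibition, read by CCK-8 assay, with a stated time of 48 h (on this read-out lower numbers stand for stronger inhibition of growth and higher numbers for weaker inhibition of growth), compound 2 `CC(C)c1ccccc1Nc1nc(Nc2ccc(N3CCN(C)CC3)cn2)ncc1Cl` gives 5140 nM, the lower of the two numbers so far, while compound 1 `Cc1cccc(Nc2nc(Nc3ccc(N4CCN(C)CC4)cn3)ncc2Cl)c1` gives 15300 nM. Compound 3 `COc1cccc(Nc2nc(Nc3ccc(N4CCN(C)CC4)cn3)ncc2Cl)c1` carries 3-methoxyphenyl in place of 2-isopropylphenyl on a nitrogen on an aromatic ring. Among the compounds with values here, the one measured step that bears on this is a 3.0-fold lower number from compound 1 to compound 2 (0.47 log units; beyond the scatter), which brought in 2-isopropylphenyl in place of 3-methylphenyl. The 3-methoxyphenyl group resembles that 3-methylphenyl group by name, so most of that step should reverse in this assay. The expected change is a 2.3-fold higher number from compound 2 to compound 3 (0.37 log units; beyond the scatter), towards weaker inhibition of growth. For compound 3 the estimated value is 12000 nM, with an expected range from 5500 nM to 26000 nM.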

Compound 3, concentration for 50% growth inhibition: 15800 nM
Beside the measured number, compound 3's estimate is 1.3-fold (0.12 log units) below it; low and high end bracket the measured number.
By their numbers in this assay, from the lowest: compound 2; then compounds 1 and 3 (each within the scatter of the next).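

this assay records a 3.1-fold higher number from compound 2 to compound 3 (0.49 log units; beyond the scatter) and so the lower number seen with 2-isopropylphenyl does not carry over to 3-methoxyphenyl. Methoxy in place of methyl on an aromatic carbon gives a 1.0-fold higher number from compound 1 to compound 3 (0.01 log units; within the scatter) and so these two groups read alike here. Nothing measured here explains these results. Compound 2 differs from compounds 1 and 3 in both its group and where that group sits on the phenyl ring, so the two influences remain unseparated. On these data alone, how an amine or a carboxylic acid on that ring would read also remains open.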